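The compounds below may be only part of what the source reports. "The series", "measured", "known", "first", "only" and "open" are said of these compounds alone.

Measured so far:
compound 1, `COc1cc(N(C)CCN(C)C)c(NC(=O)c2ccncn2)cc1Nc1nccc(-c2cn(C)c3ccccc23)n1`, 2530 nM;
compound 2, `COc1cc(N(C)CCN(C)C)c(NC(=O)c2ncccn2)cc1Nc1nccc(-c2cn(C)c3ccccc23)n1`, 2490 nM;
compound 3, `COc1cc(N(C)C)c(NC(=O)c2ccncn2)cc1Nc1nccc(-c2cn(C)c3ccccc23)n1`, 5160 nM.

All three were tested in a functional assay on A549 cells (Homo sapiens) for antiproliferative activity, read by MTT assay, with a stated time of 72 h; a lower number here means a stronger inhibitor, a higher number a weaker inhibitor. Compound 1 and compound 2 differ only by pyrimidin-2-yl in place of pyrimidin-4-yl on a carbonyl carbon, and that change made a 1.0-fold lower number from compound 1 to compound 2 (0.01 log units; within the scatter). Compound 3 differs from compound 1 by hydrogen in place of (dimethylamino)methyl on a saturated chain carbon bound to a nitrogen on an aromatic ring, which gave a 2.0-fold higher number from compound 1 to compound 3 (0.31 log units; beyond the scatter).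

Compound 4, `COc1cc(N(C)C)c(NC(=O)c2ncccn2)cc1Nc1nccc(-c2cn(C)c3ccccc23)n1`, is not yet measured. It differs from compound 3 by pyrimidin-2-yl in place of pyrimidin-4-yl on a carbonyl carbon, the same change as from compound 1 to compound 2, made on the core of compound 3. Because that change gave a 1.0-fold lower number from compound 1 to compound 2 (0.01 log units; within the scatter), the step from compound 3 to compound 4 is expected to be similar, about a 1.0-fold lower number from compound 3 to compound 4 (0.01 log units; within the scatter). Compound 4 is therefore estimated at 5000 nM in this assay, most likely between 2500 nM and 10000 nM.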

Compound 4, half-maximal inhibitory concentration: 8640 nM
Compound 4: the middle estimate sits 1.7-fold (0.24 log units) below what was measured; low and high end bracket the measured number.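

Putting pyrimidin-2-yl in place of pyrimidin-4-yl on the carbonyl carbon gave a 1.7-fold higher number from compound 3 to compound 4 (0.22 log units; within the scatter) in this assay, and this change carried over between the two cores: the same change on two cores in this assay, a 1.0-fold lower number (0.01 log units; within the scatter) from compound 1 to compound 2 and a 1.7-fold higher number (0.22 log units; within the scatter) from compound 3 to compound 4, 1.7-fold (0.23 log units) apart, within the scatter of two such steps. Putting hydrogen in place of (dimethylamino)methyl gave a 3.5-fold higher number from compound 2 to compound 4 (0.54 log units; beyond the scatter), and this change also carried over: the same change on two cores in this assay, a 2.0-fold higher number (0.31 log units; beyond the scatter) from compound 1 to compound 3 and a 3.5-fold higher number (0.54 log units; beyond the scatter) from compound 2 to compound 4, 1.7-fold (0.23 log units) apart, within the scatter of two such steps. This shows that each change behaved alike on these two cores in this one cell assay, but it does not show that either would do so on a third core.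

The compounds shown leave open what a phenyl group would do on the carbonyl carbon. They also leave open what (diethylamino)methyl would do in place of (dimethylamino)methyl.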